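The source may hold more compounds than are shown below. What is called first, only, known or untested is meant among the compounds shown, and "the series" means these compounds.

Measured compounds:
- compound 1 `COc1cc(-c2ccnc3cc(-c4ccc5cc[nH]c5c4)nn23)cc(OC)c1OC`, 187 nM
- compound 2 `COc1ccc(-c2cc3nccc(-c4cc(OC)c(OC)c(OC)c4)n3n2)cc1[N+](=O)[O-]`, > 10000 nM
- compound 3 `COc1cc(-c2cc3nccc(-c4c[nH]c5ccccc45)n3n2)cc(OC)c1OC`, > 10000 nM

Among the measured compounds shown here, in a functional assay on HCT-116 cells (Homo sapiens) for inhibition, read by CCK-8 assay, with a stated time of 48 h (a higher number here means a weaker inhibitor, a lower number a stronger inhibitor), compound 1 gives 187 nM, the only numerical value so far. Compound 2 returns > 10000 nM, which is a limit of this assay and not a number. Compound 3 likewise returns > 10000 nM, again a limit. For the measured compounds named here, the picture is therefore (the limit of > 10000 nM in this assay, at which 2 of the 3 values shown sit), with compound 1 standing alone as the one compound that registers within range. Going by the values given here, no pair of measured compounds differs in a single place, so no step within the measured set can be sized.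

Compound 4 `COc1cc(-c2ccnc3cc(-c4ccc(N(C)C)cc4)nn23)cc(OC)c1OC` is not yet measured. It keeps the core and the trimethoxyphenyl arrangement of compound 1 and alters one substituent: 4-(dimethylamino)phenyl in place of 1H-indol-6-yl on an aromatic carbon. The leaving and entering groups match in heavy-atom count, but the hydrogen-bond donor of the 1H-indol-6-yl is exchanged for the acceptor of the 4-(dimethylamino)phenyl, and the fused five-membered ring is lost.

Among the compounds with values here, since compound 1 is the sole anchor with a number, the expectation for compound 4 rests on it alone: a modest loss is expected, a 2.4-fold higher number from compound 1 to compound 4 (0.38 log units; beyond the scatter), beyond the scatter but well short of the limit. Compound 4 is thus estimated at 450 nM, with a range from 90 nM to 3000 nM.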

Compound 4, half-maximal inhibitory concentration: 2050 nM
Compound 4: middle estimate off by 4.6-fold (0.66 log units), on the low side; low and high end bracket the measured number.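

In this assay, placing 4-(dimethylamino)phenyl instead of 1H-indol-6-yl on this aromatic carbon, next to the ring nitrogen, gives an 11-fold higher number from compound 1 to compound 4 (1.04 log units; beyond the scatter). Among the compounds shown here, this is the first step that can be sized, and it shows that this place is sensitive to the group it carries, even when the leaving and entering groups match in heavy-atom count. Compound 4 still returns a number, so this change weakens the compound without bringing it to the limit: the limit of > 10000 nM in this assay, at which 2 of the 4 values shown sit.

This single step changes several things together: the hydrogen-bond donor is lost, a hydrogen-bond acceptor enters, and the fused five-membered ring is gone, so the compounds shown cannot assign the loss to any one of these. As far as these compounds go, it also remains open whether a simple phenyl, a primary amine or a methoxy group on the phenyl ring at this place would stay close to compound 1 at 187 nM, or whether a different fused ring such as a benzimidazole would hold that level.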